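Naphthalene in Place of tert-Butylphenyl on the Amine

The source may hold more compounds than are shown below. What is called first, only, known or untested is meant among the compounds shown, and "the series" means these compounds.

Compound 1, `CCc1ccc2[nH]c(=O)c(CN(Cc3ccc(F)cc3)Cc3ccc(C(C)(C)C)cc3)cc2c1`: > 33000 nM
Compound 2, `CCc1ccc2[nH]c(=O)c(CN(Cc3ccc(C(C)(C)C)cc3)Cc3ccc(F)c(F)c3)cc2c1`: > 33000 nM
Compound 3, `CC(C)c1ccc2[nH]c(=O)c(CN(Cc3ccc(F)cc3)Cc3ccc(C(C)(C)C)cc3)cc2c1`: 7900 nM

In a toxicity assay on MDCK cells (Canis lupus familiaris) for cytotoxicity, read by crystal violet staining, with a stated time of 48 h (on this read-out lower numbers stand for higher toxicity in this test and higher numbers for lower toxicity in this test), compound 1 gives > 33000 nM, which is a limit of the test rather than a number. Compound 2 likewise gives > 33000 nM, again a limit. Among the measured compounds shown here, compound 3 gives 7900 nM, the only numeric value here. The readable step, an at least 4.1-fold lower number from compound 1 to compound 3 (0.62 log units; beyond the scatter), sits on the core, while a step that the two limits leave unreadable from compound 1 to compound 2 concerns the other benzyl ring and is hidden by the limits; neither touches the change in question. Compound 4, `CCc1ccc2[nH]c(=O)c(CN(Cc3ccc(F)cc3)Cc3ccc4ccccc4c3)cc2c1`, differs from compound 1 by naphthalen-2-yl in place of 4-(tert-butyl)phenyl on a saturated chain carbon bound to an amine nitrogen. With the limit of > 33000 nM in this assay, at which 2 of the 3 values shown sit, as the only anchor, compound 4 is expected to stay near that limit, estimated at 30000 nM, within 8000 nM to 100000 nM. This expectation amounts to an at least 1.1-fold lower number from compound 1 to compound 4 (0.04 log units; that floor lies within the scatter).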

Compound 4, half-maximal cytotoxic concentration: > 5000 nM
Compound 4 ended at the assay's limit; the forecaster's own chance of this, stated with the estimate: 60%; the middle value lies beyond the limit too.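

Among the compounds shown here, the results for compound 1 and compound 4 are both limits of the test, and no step between them can be read. The compounds shown leave open whether naphthalen-2-yl in place of 4-(tert-butyl)phenyl changes the toxicity reading at all, and in which direction.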